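The compounds below may be only part of what the source reports. "The series", "measured", "known", "first", "only" and "open" are said of these compounds alone.

Of the compounds shown here, two have so far been measured in a functional assay on CHO cells for antagonist activity at prostaglandin E2 receptor EP3 subtype (Homo sapiens), read by cAMP accumulation; on this read-out lower numbers stand for stronger inhibition and higher numbers for weaker inhibition. Compound 1, with the structure `CCn1ncc2c(F)cc(-c3ccc(C(CC)(CC)c4nnc(C)[nH]4)c(=O)[nH]3)cc21`, gives 90 nM in this assay. Compound 2, with the structure `CC(C)C(Nc1nccs1)c1ccc(-c2ccc3cccc(F)c3c2)[nH]c1=O`, gives 10 nM in this assay, the lower of the two numbers; the gap between compound 2 and compound 1 is beyond the usual scatter of repeated measurements.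

Compound 3, with the structure `CC(C)NC(=O)CC(c1ccc(-c2ccc3cccc(F)c3c2)[nH]c1=O)C(C)C`, has not yet been measured. It differs from compound 2 in one place: (isopropylcarbamoyl)methyl in place of (1,3-thiazol-2-yl)amino on a saturated chain carbon bound to an aromatic carbon and a saturated chain carbon. For the measured compounds named here, only these two values are known, and no measured pair shares exactly this change. The size of the step can therefore only be judged loosely. A change of this kind, swapping a ring-bearing amino group for an open chain amide, is expected to move the number upward, and the estimated step from compound 2 to compound 3 is a 6.0-fold higher number from compound 2 to compound 3 (0.78 log units; beyond the scatter). Compound 3 is therefore expected to give about 60 nM in this assay, with a likely range from 15 nM to 300 nM.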

Compound 3, half-maximal inhibitory concentration: 15 nM
Compound 3: the middle estimate sits 4.0-fold (0.60 log units) above what was measured; low and high end bracket the measured number.
By their numbers in this assay, from the lowest: compounds 2 and 3 (each within the scatter of the next); then compound 1.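

In this assay, the swap at this place gives a 1.5-fold higher number from compound 2 to compound 3 (0.18 log units; within the scatter), so compound 2 and compound 3 cannot be told apart. For the compounds shown here, this is the first sign that, on this saturated chain carbon, the five-membered aromatic ring of (1,3-thiazol-2-yl)amino is not needed to keep the number in this range: (isopropylcarbamoyl)methyl, which has no ring and no sulfur, does as well within the scatter. No measurement is available that explains why these two different groups match.

The compounds shown leave open which part of the new group counts, since only the complete (isopropylcarbamoyl)methyl group can be judged here. A carboxylic acid, a plain primary amide or a longer chain on the amide nitrogen at this carbon would help separate the roles of the amide and its isopropyl end.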